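This account rests on a few compounds, and the source may have more. Where it says the series, first, only, none or still open, it means among the compounds named here.

In a functional assay on DU-145 cells (Homo sapiens) for antiproliferative activity, read by WST assay, with a stated time of 72 h (on this read-out higher numbers stand for an effect only at larger amounts of compound and lower numbers for an effect already at smaller amounts), three compounds have numbers or limits so far. Compound 2 `CCCCCCCC/C=C\c1c(C)c(/C=C\CCCCCCCC)c2[n+](c1C)CCC2` gives 1 uM, and compound 3 `CCCCCCCCCCc1c(C)cc(C)[n+]2c1CCC2` gives 0.5 uM. These two values lie within the usual scatter of each other, so compound 2 stands level with compound 3 on this read-out. For compound 1 `CCCCCCCC/C=C\c1c(C)cc(C)nc1CCCOC` the assay reports only a limit, > 30 uM.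

Compound 4 `CCCCCCCC/C=C\c1c(C)cc(C)[n+]2c1CCC2` has not yet been measured. It differs from compound 2 in one place: hydrogen in place of dec-1-en-1-yl on an aromatic carbon. Hydrogen takes the place of dec-1-en-1-yl on an aromatic carbon, two atoms from the ring nitrogen and ortho to two methyl groups.

Among the compounds with values here, no pair of measured compounds shows this change on its own, so the expectation is indirect. In this assay no shift beyond the scatter is expected, and no firm direction can be given. The basis for this is that compound 2 at 1 uM and compound 3 at 0.5 uM sit so close together, and compound 4 is expected to fall in the same region. The estimated change is small, a 1.4-fold lower number from compound 2 to compound 4 (0.15 log units; within the scatter). For compound 4 the expected value is 0.7 uM, with an estimated range from 0.25 uM to 2 uM.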

Compound 4, concentration for half-maximal effect: 0.2 uM
Estimate against measurement, compound 4: 3.5-fold (0.54 log units) above; measured number outside the range, below it.
By their numbers in this assay, from the lowest: compound 4; then compounds 3 and 2 (each within the scatter of the next). At a limit, above all of these: compound 1.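

In this assay, hydrogen in place of dec-1-en-1-yl on the aromatic carbon two atoms from the ring nitrogen, ortho to two methyl groups, gives a 5.0-fold lower number from compound 2 to compound 4 (0.70 log units; beyond the scatter). Within the data shown here, this is the first direct reading of this position, and although the step is modest, it shows that the dec-1-en-1-yl group at this carbon is not required for the effect on this read-out: the compound with only hydrogen there acts at a smaller amount, while keeping its other dec-1-en-1-yl group. Nothing among the data shown bears on why this step occurs.

With only hydrogen and dec-1-en-1-yl to compare at this carbon, the compounds shown leave open how an intermediate group would read there, such as a methyl group, a butyl chain, an amine or a carboxylic acid, and so whether the number rises steadily with chain length or only once a long chain is present. They also leave open what happens when the remaining dec-1-en-1-yl group is replaced by hydrogen or by a shorter chain, as every compound shown carries a long chain on the ring.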